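Sec-Butyl Ester to Diethylamide on a Dienoate Chain

The source may report more compounds than this note shows. Statements on the series, on what has been measured and on what is new or still open speak of the compounds shown alone.

Compound 1 `CCC(C)OC(=O)/C=C(C)/C=C/CC(C)CCCC(C)C`: 7.69
Compound 2 `CCOC(C)(C)CCCC(C)C/C=C/C(C)=C/C(=O)OC(C)C`: 6.49

In a physicochemical assay for lipophilicity (on this read-out higher numbers stand for higher lipophilicity and lower numbers for lower lipophilicity), compound 1 stands at the higher of the two measured numbers, and compound 2 lies lower by a gap beyond the scatter. Compound 3 `CCN(CC)C(=O)/C=C(C)/C=C/CC(C)CCCC(C)C` has not yet been measured. Against compound 1 the change is diethylamino in place of sec-butoxy on a carbonyl carbon. For the measured compounds named here, no measured pair shows this change, so any expectation rests on the structural difference alone. The step of a number 1.39 log units lower from compound 1 to compound 3 (beyond the scatter) is expected to be a drop beyond the scatter, of moderate size. Compound 3 is therefore estimated at 6.3, with a likely range from 5.6 to 7.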

Compound 3, partition coefficient: 6.02
For compound 3 the middle estimate is 0.28 log units above the measured one; measured number inside the range.
By their numbers in this assay, from the lowest: compound 3; then compound 2; then compound 1.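

In this assay, for the compounds shown here, diethylamino in place of sec-butoxy on a carbonyl carbon gives a number 1.67 log units lower from compound 1 to compound 3 (beyond the scatter) on an unchanged chain, the first comparison here that differs in one place. The two groups have the same heavy-atom count, so this large step comes with nitrogen replacing oxygen rather than with a change in that count. Nothing measured here accounts for the step. As far as these compounds go, it remains open whether a dimethylamino group or a carboxylic acid on this carbonyl carbon would give a similar step. From the compounds shown here alone, it is also open whether diethylamino would have the same effect on the chain of compound 2.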